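Swapping the five-membered ring on the shared core

The source may hold more compounds than are shown below. What is called first, only, known or untested is meant among the compounds shown, and "the series" means these compounds.

Measured compounds:
compound 1, `O=C(NCCC1CC1)c1ccc(N2CCC(Oc3ccccc3C(F)(F)F)CC2)nn1`, 14 nM
compound 2, `FC(F)(F)c1ccccc1OC1CCN(c2ccc(-n3ccnc3)nn2)CC1`, 4 nM
compound 3, `OCc1nnc(-c2ccc(N3CCC(Oc4ccccc4C(F)(F)F)CC3)nn2)o1`, 2.9 nM

In an assay on microsomes from liver for inhibition of acyl-CoA desaturase 1 (Rattus norvegicus) (a higher number here means a weaker inhibitor, a lower number a stronger inhibitor), compound 3 gives the lowest number of the three, though its separation from compound 2 is only a 1.4-fold lower number from compound 2 to compound 3 (0.14 log units; within the scatter), within the scatter. The clear step is from the amide in compound 1: a 4.8-fold lower number from compound 1 to compound 3 (0.68 log units; beyond the scatter), and the related change to compound 2 gave a 3.5-fold lower number from compound 1 to compound 2 (0.54 log units; beyond the scatter).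

Compound 4, `Cc1nnc(-c2ccc(N3CCC(Oc4ccccc4C(F)(F)F)CC3)nn2)s1`, is not yet measured. It differs from compound 3 by 5-methyl-1,3,4-thiadiazol-2-yl in place of 5-(hydroxymethyl)-1,3,4-oxadiazol-2-yl on an aromatic carbon. The change therefore keeps a small aromatic ring at the same place and removes the hydrogen-bond donor. Among the measured steps, the one from compound 2 to compound 3 is the closest guide, since both carry a small five-membered ring there, and that step stayed within the scatter. On that basis compound 4 is expected to sit close to compound 3 in this assay, with a step of a 1.4-fold higher number from compound 3 to compound 4 (0.14 log units; within the scatter), no firm direction. The estimate for compound 4 is 4 nM, in a range from 1.5 nM to 12 nM.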

Compound 4, half-maximal inhibitory concentration: 2.3 nM
Beside the measured number, compound 4's estimate is 1.7-fold (0.24 log units) above it; the measured number falls inside the stated range.
By their numbers in this assay, from the lowest: compounds 4, 3 and 2 (each within the scatter of the next); then compound 1.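

In this assay, the change of ring and side group gives a 1.3-fold lower number from compound 3 to compound 4 (0.10 log units; within the scatter), so this position accepts a sulfur-containing ring with a plain methyl and 0 hydrogen-bond donors on the entering group without a change beyond the scatter. The comparison with the imidazole gives a 1.7-fold lower number from compound 2 to compound 4 (0.24 log units; within the scatter), which means that the three five-membered aromatic rings cannot be told apart in this assay. Only the comparison with the amide stands out, at a 6.1-fold lower number from compound 1 to compound 4 (0.78 log units; beyond the scatter) and beyond the scatter, so compound 4 joins compound 2 and compound 3 in differing clearly from compound 1.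

Because sulfur replaces oxygen and methyl replaces hydroxymethyl at once, the effect of each remains unresolved, as does the outcome with an amine or a longer chain on the ring. No measured evidence bears on what lies behind these numbers.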